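The source may report more compounds than this note shows. Statements on the series, on what has been measured and on what is new or still open speak of the compounds shown alone.

Of the compounds shown here, three have been measured in an ADME assay on MRC5 cells (Homo sapiens), read by MTT assay, with a stated time of 72 h (a lower number here means a stronger inhibitor, a higher number a weaker inhibitor), and a fourth has not. Compound 1 `Cc1nc(N)c2c(-c3ccccc3)cn([C@@H]3O[C@H](CO)[C@@H](O)[C@H]3O)c2n1` carries a phenyl group on its core, while compound 2 `Cc1nc(N)c2c(-c3cccs3)cn([C@@H]3O[C@H](CO)[C@@H](O)[C@H]3O)c2n1` carries thiophen-2-yl at the same place. Compound 3 `COc1ncnc2c1c(-c1cccs1)cn2[C@@H]1O[C@H](CO)[C@@H](O)[C@H]1O` also carries thiophen-2-yl, but on a different core; the difference between the two cores is not broken down here. Compound 4 `COc1ncnc2c1c(-c1ccccc1)cn2[C@@H]1O[C@H](CO)[C@@H](O)[C@H]1O` is the phenyl counterpart of compound 3.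

In this assay compound 1 gives only a limit, > 100000 nM. Compound 2 also gives only a limit, > 100000 nM. Within the data shown here, compound 3 gives 43200 nM, the one actual number among the three. The change from compound 2 to compound 1 is phenyl in place of thiophen-2-yl on an aromatic carbon, and its step that the two limits leave unreadable from compound 2 to compound 1 cannot be read because the limit of > 100000 nM in this assay, at which 2 of the 3 values shown sit, covers both ends.

The change from compound 3 to compound 4 is the same one, (phenyl in place of thiophen-2-yl on an aromatic carbon), at a place described in identical words. The measured version of this change gives no readable size, so the expectation for compound 4 rests on compound 3 at 43200 nM alone, treating the ring exchange as roughly neutral. In this assay the expected step is a 1.2-fold higher number from compound 3 to compound 4 (0.06 log units; within the scatter). Compound 4 is accordingly estimated at 50000 nM, with the estimate expected to fall between 18000 nM and 150000 nM.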

Compound 4, half-maximal inhibitory concentration: > 100000 nM
Compound 4 ended at the assay's limit (the forecaster's own chance of this, stated with the estimate: 35%); middle value at least 2.0-fold (0.30 log units) from the limit.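

In this assay, putting phenyl in place of thiophen-2-yl on an aromatic carbon gives an at least 2.3-fold higher number from compound 3 to compound 4 (0.36 log units; beyond the scatter), so on this core the exchange costs activity by more than the usual scatter of repeated measurements. From the compounds shown here alone, compound 4 gives only a limit, > 100000 nM, so the step is a minimum and its full size remains unknown. The result does not show that the change carries over from one core to the other, since the matching step from thiophen-2-yl to phenyl on the core of compound 1 and compound 2 cannot be read, because both ends of that pair sit at the same limit: the limit of > 100000 nM in this assay, at which 3 of the 4 values shown sit.

Among these compounds, the series therefore offers one readable pair on one core, and a single pair cannot establish a trend, while only two groups, thiophen-2-yl and phenyl, appear at this place on the two cores. Going by these compounds, what an amine, a carboxylic acid or a longer chain at the same aromatic carbon would do in this assay stays open, as does whether any compound on the core of compound 1 and compound 2 would give an actual number rather than a limit.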